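A few compounds are considered here, and "the series" means these few. Any claim that something is new, unique, unknown or untested is made for them only; others in the source may bear on it.

Compound 1 `O=C(N/N=C/c1ccc(F)cc1)Nc1cc2c(Nc3ccc(F)c(Cl)c3)ncnc2cc1O[C@H]1CCOC1` belongs to a small set of close relatives tested in a functional assay on A549 cells (Homo sapiens) for cytotoxicity, read by MTT assay, with a stated time of 72 h; on this read-out lower numbers stand for stronger inhibition and higher numbers for weaker inhibition. In this assay compound 1 gives 35100 nM, compound 2 `O=C(N/N=C/c1ccc(F)cc1Cl)Nc1cc2c(Nc3ccc(F)c(Cl)c3)ncnc2cc1O[C@H]1CCOC1` gives 27200 nM, and compound 3 `COc1ccc(/C=N/NC(=O)Nc2cc3c(Nc4ccc(F)c(Cl)c4)ncnc3cc2O[C@H]2CCOC2)c(OC)c1OC` gives 25200 nM. The three numbers sit close together: a 1.3-fold lower number from compound 1 to compound 2 (0.11 log units; within the scatter) and a 1.4-fold lower number from compound 1 to compound 3 (0.14 log units; within the scatter), and a 1.1-fold lower number from compound 2 to compound 3 (0.03 log units; within the scatter).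

Compound 4 `O=C(N/N=C/c1ccc(O)cc1O)Nc1cc2c(Nc3ccc(F)c(Cl)c3)ncnc2cc1O[C@H]1CCOC1` has not been measured. It differs from compound 1 in one place: 2,4-dihydroxyphenyl in place of 4-fluorophenyl on a carbon with a double bond to nitrogen. The step from compound 1 to compound 3 and the step from compound 2 to compound 3 change the same aromatic group on the carbon with a double bond to nitrogen, and both stayed within the scatter. A similar outcome is therefore expected here, with a 1.2-fold lower number from compound 1 to compound 4 (0.07 log units; within the scatter). For compound 4 the expected value is 30000 nM, within a range of 12000 nM to 75000 nM.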

Compound 4, half-maximal inhibitory concentration: 9360 nM
Compound 4: middle estimate off by 3.2-fold (0.51 log units), on the high side, and the stated range ends above it.
By their numbers in this assay, from the lowest: compound 4; then compounds 3, 2 and 1 (each within the scatter of the next).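

Among the earlier compounds, changing the aromatic group on the carbon with a double bond to nitrogen gave no step beyond the scatter in this assay. Here 2,4-dihydroxyphenyl gives a 3.8-fold lower number from compound 1 to compound 4 (0.57 log units; beyond the scatter), a 2.7-fold lower number from compound 3 to compound 4 (0.43 log units; beyond the scatter) and a 2.9-fold lower number from compound 2 to compound 4 (0.46 log units; beyond the scatter), so the number at this place can respond to the group it carries. The entering group has hydrogen-bond donors and 4-fluorophenyl has none, but no measurement shown explains the step.

The compounds shown leave open whether a phenyl group with a single hydroxyl, or an amino group in place of the hydroxyls, would give a similar step.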